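A few compounds are considered here, and "the series" means these few. Any claim that something is new, unique, unknown or untested is made for them only; others in the source may bear on it.

Measured so far:
compound 1 `FC(F)(F)c1ccc(CSc2nc(Nc3cccc(C(F)(F)F)c3)c3ccccc3n2)cc1`, 12900 nM
compound 2 `FC(F)(F)c1ccc(CSc2nc(Nc3cccc(Cl)c3)c3ccccc3n2)cc1`, 13400 nM
compound 3 `FC(F)(F)c1ccc(CSc2nc(Nc3ccc(Cl)cc3)c3ccccc3n2)cc1`, 7110 nM

All three were tested in a functional assay on PC-3 cells (Homo sapiens) for cytotoxicity, read by MTT assay, with a stated time of 72 h; on this read-out lower numbers stand for stronger inhibition and higher numbers for weaker inhibition. Compound 3 is set against compound 1 and compound 2 through the steps of a 1.8-fold lower number from compound 1 to compound 3 (0.26 log units; within the scatter) and a 1.9-fold lower number from compound 2 to compound 3 (0.28 log units; within the scatter). Both of these fall within the usual scatter of repeated measurements of this kind, so on the numbers at hand the three compounds cannot be told apart.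

Compound 4 `FC(F)(F)c1ccc(CSc2nc(Nc3ccc(C(F)(F)F)cc3)c3ccccc3n2)cc1` has not yet been measured. It differs from compound 3 in a single place: trifluoromethyl in place of chloro on an aromatic carbon. Going by the values given here, only one measured step involves the same pair of groups, and it runs in the reverse direction at a different spot on the same ring: a 1.0-fold higher number from compound 1 to compound 2 (0.02 log units; within the scatter), a step within the scatter. Among the compounds with values here, that is thin evidence, but it is the only direct guide. On this basis no movement beyond the scatter is expected in this assay when going from compound 3 to compound 4, and the expected step is a 1.1-fold higher number from compound 3 to compound 4 (0.02 log units; within the scatter). Compound 4 is therefore estimated at 7500 nM, with a range from 3000 nM to 18000 nM. The range is kept wide to reflect how little comparable data exists.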

Compound 4, half-maximal inhibitory concentration: 7880 nM
Beside the measured number, compound 4's estimate is 1.1-fold (0.02 log units) below it; the range from low to high includes it.
By their numbers in this assay, from the lowest: compounds 3, 4, 1 and 2 (each within the scatter of the next).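

In this assay, the exchange of chloro for trifluoromethyl has now been tested on an aromatic carbon para to a large group, and it gives a 1.1-fold higher number from compound 3 to compound 4 (0.04 log units; within the scatter), so this position shows no response to the change that can be told from noise. The exchange between these two groups now reads the same in two places on this ring, where earlier there was a single example, and the two steps cannot be told apart: the same change on two cores in this assay, a 1.0-fold higher number (0.02 log units; within the scatter) from compound 1 to compound 2 and a 1.1-fold lower number (0.04 log units; within the scatter) from compound 4 to compound 3, 1.2-fold (0.06 log units) apart, within the scatter of two such steps The new compound also gives two comparisons with the 3-substituted compounds, a 1.6-fold lower number from compound 1 to compound 4 (0.21 log units; within the scatter) and a 1.7-fold lower number from compound 2 to compound 4 (0.23 log units; within the scatter), so replacing either of those rings with 4-(trifluoromethyl)phenyl likewise produces no separation.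

As far as these compounds go, all four compounds carry either chloro or trifluoromethyl on this ring, so it remains open whether a quite different group there, such as an amine or a carboxylic acid, would produce a step beyond the scatter. The rest of the shared core is identical throughout, which leaves the effect of any change outside this ring unknown as well.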